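Shifting the Fluorine from Compound 3 to Compound 4

This account rests on a few compounds, and the source may have more. Where it says the series, first, only, none or still open, it means among the compounds named here.

Measured compounds:
- compound 1, `Fc1ccccc1COc1ccc(-c2cc(CN3CCN(Cc4ccc(C(F)(F)F)cc4)CC3)no2)cc1`: 1500 nM
- compound 2, `Fc1cccc(COc2ccc(-c3cc(CN4CCN(Cc5ccc(C(F)(F)F)cc5)CC4)no3)cc2)c1`: 1300 nM
- compound 3, `N#Cc1cccc(COc2ccc(-c3cc(CN4CCN(Cc5ccccc5F)CC4)no3)cc2)c1`: 2400 nM

All three were tested in a functional assay on Huh-7 cells (Homo sapiens) for antiproliferative activity, read by sulforhodamine B assay, with a stated time of 72 h; on this read-out higher numbers stand for weaker inhibition and lower numbers for stronger inhibition. Compound 1 and compound 2 differ by 3-fluorophenyl in place of 2-fluorophenyl on a saturated chain carbon bound to an oxygen on an aromatic ring, and this change gave a 1.2-fold lower number from compound 1 to compound 2 (0.06 log units; within the scatter). Compound 3 gives the highest of the three numbers in this assay, but its gaps to compound 1 and compound 2 are both within the scatter. How the core of compound 3 differs from the core of compound 1 is not broken down here.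

Compound 4, `N#Cc1cccc(COc2ccc(-c3cc(CN4CCN(Cc5cccc(F)c5)CC4)no3)cc2)c1`, is not yet measured. It differs from compound 3 by 3-fluorophenyl in place of 2-fluorophenyl on a saturated chain carbon bound to an amine nitrogen in a ring. This is the same kind of change as that from compound 1 to compound 2, but not the same: there the place is on a saturated chain carbon bound to an oxygen on an aromatic ring, here on a saturated chain carbon bound to an amine nitrogen in a ring. Compound 4 is expected to show a 1.2-fold lower number from compound 3 to compound 4 (0.08 log units; within the scatter), an expectation resting on the small step seen in a 1.2-fold lower number from compound 1 to compound 2 (0.06 log units; within the scatter). Compound 4 is estimated at 2000 nM, with a likely range from 1000 nM to 4500 nM.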

Compound 4, half-maximal inhibitory concentration: 2700 nM
Compound 4: the middle estimate sits 1.4-fold (0.13 log units) below what was measured; the measured number falls inside the stated range.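

In this assay, 3-fluorophenyl in place of 2-fluorophenyl on a saturated chain carbon bound to an amine nitrogen in a ring gave a 1.1-fold higher number from compound 3 to compound 4 (0.05 log units; within the scatter). Set beside the earlier pair, where the change stood on a saturated chain carbon bound to an oxygen on an aromatic ring, the two steps do not differ: the same change on two cores in this assay, a 1.2-fold lower number (0.06 log units; within the scatter) from compound 1 to compound 2 and a 1.1-fold higher number (0.05 log units; within the scatter) from compound 3 to compound 4, 1.3-fold (0.11 log units) apart, within the scatter of two such steps. This shows that the change left no readable mark in either of these two pairs, but with one pair per core it does not show that the change would be as silent on any other core in the series.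

The compounds shown leave open what happens when the fluorophenyl group on the chain carbon bound to the ring amine nitrogen gives way to a plain phenyl, a chlorophenyl or a methoxyphenyl.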